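A few compounds are considered here, and "the series" means these few. Any claim that something is new, unique, unknown or untested is made for them only; others in the source may bear on it.

In a functional assay on MDA-MB-231 cells (Homo sapiens), read by microscopy and transwell migration, with a stated time of 24 h (a higher number here means a weaker inhibitor, a lower number a stronger inhibitor), compound 1 (`C#CCn1c(-c2ccc(C)cc2C)cs/c1=N\C(=O)c1ccccc1`) gives 3890 nM. Compound 2 (`COc1cc(-c2csc(NC(=O)c3ccccc3)n2)cc(OC)c1OC`) reads > 50000 nM, a limit of the assay and not a number, and so stands at the limit of > 50000 nM in this assay, at which 1 of the 2 values shown sits. Compound 3 (`COc1ccc(C(=O)Nc2nc(-c3cc(OC)c(OC)c(OC)c3)cs2)cc1`) has methoxy in place of hydrogen on an aromatic carbon, para to a large group: methoxy in place of hydrogen on an aromatic carbon. Among the measured compounds shown here, no measured pair shows the size of such a change. The expected at least 1.4-fold lower number from compound 2 to compound 3 (0.15 log units; that floor lies within the scatter) in this assay is small, towards stronger inhibition, and the reading may well stay at the limit. Compound 3 is estimated at 35000 nM, with an expected range of 6000 nM to 50000 nM.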

Compound 3, half-maximal inhibitory concentration: > 25000 nM
Compound 3: only a limit was reported; the forecaster's own chance of this, stated with the estimate: 55%; the middle value is on the limit's open side.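

In this assay compound 2 reads > 50000 nM, a limit of the assay. Compound 3 reads > 25000 nM, also a limit, and no step can be read between compound 2 and compound 3. Left open is whether methoxy in place of hydrogen on an aromatic carbon changes inhibition at all.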